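Cyanoguanidine series: chain extension on the compound 2 ring framework

This account rests on a few compounds, and the source may have more. Where it says the series, first, only, none or still open, it means among the compounds named here.

Measured so far:
compound 1, `CC(C)CC(C)(C)/N=C(\NC#N)Nc1cccnc1`, 2.5 mg/kg
compound 2, `CCC(C)(C)/N=C(\NC#N)Nc1ccncc1`, 2.5 mg/kg

Both values come from a functional assay on the whole organism (blood, strain Wistar-Okamoto) with Rattus norvegicus as the target, with a stated time of 5 days; on this read-out lower numbers stand for an effect already at smaller amounts and higher numbers for an effect only at larger amounts of compound. Compound 1 gives 2.5 mg/kg in this assay. Compound 2 gives 2.5 mg/kg, which stands level with compound 1 at the digits recorded; the two compounds sit within the usual scatter of one another, so no order between them can be read from these two numbers. Within the data shown here, no pair differing in one place has been measured, so no step size has been observed directly.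

Compound 3, `CC(C)CC(C)(C)/N=C(\NC#N)Nc1ccncc1`, is not yet measured. It carries the ring portion of compound 2 together with the chain of compound 1. Against compound 2 the change is isopropyl in place of methyl on a saturated chain carbon, two bonds along the chain from a double-bonded nitrogen. Compound 1 already carries this longer chain with a different ring and gives 2.5 mg/kg, the same figure as compound 2, which gives no reason to expect a movement beyond the scatter in this assay. The estimated step of no change at the digits printed from compound 2 to compound 3 (within the scatter) is therefore expected to be essentially none. Compound 3 is expected to give about 2.5 mg/kg, within a range from 1 mg/kg to 6 mg/kg.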

Compound 3, minimum effective dose: 20 mg/kg
Estimate against measurement, compound 3: 8.0-fold (0.90 log units) below, outside the stated range (above it).
By their numbers in this assay, from the lowest: compounds 1 and 2 (each within the scatter of the next); then compound 3.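

In this assay isopropyl in place of methyl on a saturated chain carbon, two bonds along the chain from a double-bonded nitrogen, gives an 8.0-fold higher number from compound 2 to compound 3 (0.90 log units; beyond the scatter) and so shows that, with pyridin-4-yl on the amine nitrogen, this chain position does not tolerate the change without loss on this read-out. With the longer chain held fixed, pyridin-4-yl in place of pyridin-3-yl on an amine nitrogen gives an 8.0-fold higher number from compound 1 to compound 3 (0.90 log units; beyond the scatter), so the ring attachment also counts, which the matching figures of the two earlier compounds, differing in two places, could not reveal. No measurement at hand bears on the reason for either step.

Open, going by these compounds, is whether the chain step carries over to a compound with pyridin-3-yl on the amine nitrogen, since the step from methyl to isopropyl is seen here only with pyridin-4-yl. Also open, on these data alone, is how the read-out responds at this chain carbon to an ethyl or a cyclopropyl group, and to a phenyl ring in place of the pyridine on the amine nitrogen.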